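Trading a Cyclobutylmethyl for a Propyl on the Core

A few compounds are considered here, and "the series" means these few. Any claim that something is new, unique, unknown or untested is made for them only; others in the source may bear on it.

The three measured compounds share a benzotriazole-type core carrying an alkyl group on a ring nitrogen. Compound 1 `FC(F)(F)c1ccc(-c2ccc(Cn3nnc4ccccc43)cc2)c(Cl)c1` carries the largest substituent and in an ADME assay on microsomes from liver (Rattus norvegicus, strain Wistar) for metabolic stability, tested at 2.5 uM (a lower number here means slower removal, a higher number faster removal of the compound), compound 1 gives 0.5 mL/min/g. Compound 2 `Brc1cccc2c1nnn2CC1CCCCC1` is much simpler and in this assay compound 2 gives 16.2 mL/min/g. Compound 3 `Brc1cccc2c1nnn2CC1CCC1` differs from compound 2 only in ring size, and in this assay compound 3 gives 12 mL/min/g. Among these three numbers compound 3 stands second highest; its nearest neighbour is compound 2, whose value lies within the scatter of that of compound 3, while compound 1 lies far lower, beyond the scatter.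

Compound 4 `CCCn1nnc2c(Br)cccc21` is not yet measured. It differs from compound 3 by ethyl in place of cyclobutyl on a saturated chain carbon bound to an aromatic nitrogen. Since compound 2 and compound 3 sit within the scatter of each other despite their differing ring sizes, compound 3 to compound 4 is expected to show at most a small change in this assay, not clearly beyond the scatter, as a 1.2-fold lower number from compound 3 to compound 4 (0.08 log units; within the scatter). Compound 4 is therefore expected to give about 10 mL/min/g, between 5 mL/min/g and 20 mL/min/g.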

Compound 4, intrinsic clearance in a liver preparation (reported as CLH), per the amount of preparation that the assay uses: 0.8 mL/min/g
Beside the measured number, compound 4's estimate is 13-fold (1.10 log units) above it; the whole stated range lies above it.
By their numbers in this assay, from the lowest: compounds 1 and 4 (each within the scatter of the next); then compounds 3 and 2 (each within the scatter of the next).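

In this assay, ethyl in place of cyclobutyl on a saturated chain carbon bound to an aromatic nitrogen gives a 15-fold lower number from compound 3 to compound 4 (1.18 log units; beyond the scatter), so this position responds strongly to the change from cyclobutylmethyl to propyl. The earlier pair had not shown this: compound 2 gives 16.2 mL/min/g and compound 3 gives 12 mL/min/g, values within the scatter of each other, and both compounds keep a ring on the chain. Nothing available explains the large step from the ring-bearing group to the open chain.

The compounds shown leave open whether the step follows the loss of the ring or the smaller number of carbons. A longer open chain such as pentyl at this place would separate the two, and an ether or an amine within the chain would test how far the result extends.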